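Swapping the Five-Membered Ring on the Shared Core

This account rests on a few compounds, and the source may have more. Where it says the series, first, only, none or still open, it means among the compounds named here.

In an assay on isolated protein for inhibition of Thromboxane-A synthase (Homo sapiens) (on this read-out higher numbers stand for weaker inhibition and lower numbers for stronger inhibition), compound 1 `CC1(C)OC[C@@H](C/C=C\CCC(=O)O)[C@@H](c2ccnnc2)O1` gives 7400 nM. Compound 2 `CC1(C)OC[C@@H](C/C=C\CCC(=O)O)[C@@H](c2cnco2)O1` gives > 10000 nM in this assay, which is a limit of the assay rather than a number (the limit of > 10000 nM in this assay, at which 1 of the 2 values shown sits). The change between them is an at least 1.3-fold higher number from compound 1 to compound 2 (0.13 log units; that floor lies within the scatter). Compound 3 `Cn1cncc1[C@H]1OC(C)(C)OC[C@H]1C/C=C\CCC(=O)O` carries 1-methyl-1H-imidazol-5-yl in place of 1,3-oxazol-5-yl on a saturated ring carbon. Among the measured compounds shown here, only that one measured step concerns this ring, and it left compound 2 at the limit, so the size of the step for compound 3 is uncertain. The expected step for compound 3 is an at least 3.3-fold lower number from compound 2 to compound 3 (0.52 log units; beyond the scatter), toward stronger inhibition. Compound 3 is estimated at 3000 nM, between 300 nM and 10000 nM.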

Compound 3, half-maximal inhibitory concentration: 70 nM
Compound 3: middle estimate off by 43-fold (1.63 log units), on the high side; measured number outside the range, below it.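

Among the compounds shown here, the first two compounds showed no clear step at this position, but changing only this group gives an at least 140-fold lower number from compound 2 to compound 3 (2.15 log units; beyond the scatter) and a 110-fold lower number from compound 1 to compound 3 (2.02 log units; beyond the scatter). 1,3-oxazol-5-yl and 1-methyl-1H-imidazol-5-yl are both five-membered aromatic rings with 2 hetero atoms and the same counts of donors and acceptors, so those counts alone do not separate them. The step from the oxazole is only a floor, because compound 2 stands at a limit: the limit of > 10000 nM in this assay, at which 1 of the 3 values shown sits.

The compounds shown leave open whether the gain belongs to the ring nitrogen or to the methyl group. An imidazole ring without that methyl, or with an ethyl group in its place, would help separate the two.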